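Methoxy for Chloro on a Pyridazinone Amide Series

The source may hold more compounds than are shown below. What is called first, only, known or untested is meant among the compounds shown, and "the series" means these compounds.

Of the compounds shown here, two of a shared core have been tested in a functional assay on A549 cells (Homo sapiens) for cytotoxicity, read by MTT assay, with a stated time of 72 h; on this read-out higher numbers stand for weaker inhibition and lower numbers for stronger inhibition. Compound 1, with the structure `COc1ccc(-n2ccc(=O)c(C(=O)Nc3ccc(Oc4ccnc5c4ccn5C)cc3)n2)cc1`, gives in this assay only a limit of > 60000 nM, not a number. Compound 2, with the structure `Cn1ccc2c(Oc3ccc(NC(=O)c4nn(-c5ccc(Cl)cc5)ccc4=O)cc3F)ccnc21`, likewise reaches only the limit of > 60000 nM in this assay. Compound 2 therefore stands at the same limit as compound 1, and no order between the two can be read from these values; the whole picture so far is the limit of > 60000 nM in this assay, at which 2 of the 2 values shown sit.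

Compound 3, with the structure `COc1ccc(-n2ccc(=O)c(C(=O)Nc3ccc(Oc4ccnc5c4ccn5C)c(F)c3)n2)cc1`, has not yet been tested. It differs from compound 2 by one change: methoxy in place of chloro on an aromatic carbon. Going by the values given here, no measured pair shows what this exchange does in this assay, and both measured compounds sit at the limit, so no step beyond the scatter is expected in either direction. The step expected from compound 2 to compound 3 is a step that the limit leaves unreadable from compound 2 to compound 3. Compound 3 is estimated to give 80000 nM in this assay, within a range from 40000 nM to 200000 nM, most likely again reported as a limit.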

Compound 3, half-maximal inhibitory concentration: > 60000 nM
Compound 3: only a limit was reported; the forecaster's own chance of this, stated with the estimate: 85%; the middle value does not contradict the limit.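

In this assay compound 3 gives > 60000 nM, again a limit and not a number. Going by these compounds alone, no step from compound 1 or compound 2 to compound 3 can therefore be read. The picture stays as it was: the limit of > 60000 nM in this assay, at which 3 of the 3 values shown sit. Left open is whether methoxy in place of chloro, or fluoro in place of hydrogen, changes cytotoxicity at all.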